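This account rests on a few compounds, and the source may have more. Where it says the series, first, only, none or still open, it means among the compounds named here.

Measured so far in a toxicity assay on MDCK cells (Canis lupus familiaris) for cytotoxicity, read by CCK-8 assay, with a stated time of 48 h; on this read-out lower numbers stand for higher toxicity in this test and higher numbers for lower toxicity in this test:
Compound 1 `CCc1ccc(C(=O)NNc2c(Br)cccc2Br)cc1`: > 100000 nM, a limit.
Compound 2 `N#Cc1ccc(C(=O)NNc2c(Br)cccc2Br)cc1`: > 100000 nM, a limit.

Compound 2 has no numerical value, and its position is known only as the limit > 100000 nM. Across the series, the measured compounds stand at the limit of > 100000 nM in this assay, at which 2 of the 2 values shown sit.

Compound 3 `O=C(NNc1c(Br)cccc1Br)c1ccc(F)cc1` differs from compound 2 by one change: fluoro in place of cyano on an aromatic carbon. This places fluoro in place of cyano on an aromatic carbon, para to a large group.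

Among the measured compounds shown here, the only measured step bearing on this change is a step that the two limits leave unreadable from compound 1 to compound 2. It concerns the same substituent place, but its size cannot be read, as both ends are limits. It therefore gives no size or direction to carry over to the new change. For the measured compounds named here, with the limit of > 100000 nM in this assay, at which 2 of the 2 values shown sit, as the only guide, no step beyond the scatter is expected in this assay, and a further limit is the likeliest report. The expected step is a number no higher from compound 2 to compound 3 (the limit leaves the size open). For compound 3 the estimate is 100000 nM. The expected range for compound 3 runs from 50000 nM to 200000 nM.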

Compound 3, half-maximal cytotoxic concentration: > 100000 nM
Compound 3: a limit, no number (the forecaster's own chance of this, stated with the estimate: 85%); the middle value lies on the limit itself.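

Compound 3 reports a limit and not a number in this assay, so no step can be read among compound 1, compound 2 and compound 3: the limit of > 100000 nM in this assay, at which 3 of the 3 values shown sit. The compounds shown leave open whether ethyl, cyano and fluoro on this aromatic carbon differ at all in this assay.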